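Swapping a Pentyl Amide for a Morpholine Amide

The source may hold more compounds than are shown below. What is called first, only, known or untested is meant among the compounds shown, and "the series" means these compounds.

Compound 1 `CCCCNC(=O)CC1CCc2cc(OC)c(OC)cc21`: 24.1%
Compound 2 `CCCCCNC(=O)CC1CCc2cc(OC)c(OC)cc21`: 35.2%

Among the compounds with values here, in a functional assay on the whole organism (strain Wistar) for inhibition, with Rattus norvegicus as the target, read by paw edema, with stated times of 60 min and 6 h, at a dose of 100 mg/kg by the oral route (on this read-out higher numbers stand for more inhibition at the one dose given (going by the name of the read-out) and lower numbers for less inhibition), compound 2 stands highest of the two measured compounds, and the single measured step, a number 11.1 percentage points higher from compound 1 to compound 2 (beyond the scatter), lengthens the chain on the amide nitrogen. Compound 3 `COc1cc2c(cc1OC)C(CC(=O)N1CCOCC1)CC2` differs from compound 2 by morpholin-4-yl in place of pentylamino on a carbonyl carbon. The measured step concerns only chain length, so it bears weakly on this ring replacement; no measured change gives a direction, and a step within or close to the scatter is expected. Compound 3 is estimated at 30%, with a range from 15% to 45%. The expected step is a number 5.2 percentage points lower from compound 2 to compound 3 (within the scatter).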

Compound 3, a percentage reported as inhibition, in the whole organism at one dose (the size of the read-out at that dose, not a potency): 14.8%
Compound 3: the middle estimate sits 15.2 percentage points above what was measured; measured number below the stated range.
By their numbers in this assay, from the lowest: compounds 3 and 1 (each within the scatter of the next); then compound 2.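

In this assay, the group on the carbonyl carbon matters beyond chain length: morpholin-4-yl in place of pentylamino gives a number 20.4 percentage points lower from compound 2 to compound 3 (beyond the scatter). Morpholin-4-yl in place of butylamino gives a number 9.3 percentage points lower from compound 1 to compound 3 (within the scatter), so these two amides cannot be told apart here. No measurement shown explains the effect of this swap. The compounds shown leave open whether the ring, its oxygen or the missing amide hydrogen goes with the lower number, and where a piperidin-1-yl group or a hexylamino chain on the same carbonyl carbon would fall.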